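The source may report more compounds than this note shows. Statements on the series, on what has been measured and on what is new or still open speak of the compounds shown alone.

Compound 1 `Cn1c(=O)c(=O)n(C2CCCC2)c2nc(N/N=C/c3ccc(O)c(F)c3)ncc21` gives 97800 nM in a functional assay on A549 cells (Homo sapiens) for antiproliferative activity, read by MTT assay; on this read-out lower numbers stand for stronger inhibition and higher numbers for weaker inhibition. Compound 2 `Cn1c(=O)c(=O)n(C2CCCC2)c2nc(N/N=C/c3ccco3)ncc21` reaches only a limit of the assay, reported as > 100000 nM. Compound 3 `COc1ccc(/C=N/Nc2ncc3c(n2)n(C2CCCC2)c(=O)c(=O)n3C)cc1` likewise reaches only a limit, reported as > 100000 nM.

Among these three results, compound 1 is the only one reported as a number; the two others are limits, sitting at the limit of > 100000 nM in this assay, at which 2 of the 3 values shown sit. Compound 4 `Cn1c(=O)c(=O)n(C2CCCC2)c2nc(N/N=C/c3cccc([N+](=O)[O-])c3)ncc21` has not yet been tested in this assay. It differs from compound 1 in one place: 3-nitrophenyl in place of 3-fluoro-4-hydroxyphenyl on a carbon with a double bond to nitrogen. Two measured steps start from compound 1 at this same place. Exchanging the group there gave an at least 1.0-fold higher number from compound 1 to compound 2 (0.00 log units; that floor lies within the scatter) and, with a different group, an at least 1.0-fold higher number from compound 1 to compound 3 (0.00 log units; that floor lies within the scatter). Neither of these steps shows a lower number after the group on the carbon with a double bond to nitrogen is exchanged, and both end at a limit rather than at a number. For compound 4 the step is therefore expected to be either within the scatter or, like the two measured steps, an upward move toward the limit, and the expected size is a 1.0-fold higher number from compound 1 to compound 4 (0.01 log units; within the scatter). Compound 4 is estimated at 100000 nM, within an expected range from 30000 nM to 300000 nM.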

Compound 4, half-maximal inhibitory concentration: 12300 nM
Estimate against measurement, compound 4: 8.1-fold (0.91 log units) above; measured number below the stated range.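

In this assay, among these compounds, the group on the carbon with a double bond to nitrogen proves able to lower the number, which the earlier compounds did not show: exchanging 3-fluoro-4-hydroxyphenyl for 3-nitrophenyl gave an 8.0-fold lower number from compound 1 to compound 4 (0.90 log units; beyond the scatter). Set against the other two groups, the same 3-nitrophenyl gave an at least 8.1-fold lower number from compound 3 to compound 4 (0.91 log units; beyond the scatter) and an at least 8.1-fold lower number from compound 2 to compound 4 (0.91 log units; beyond the scatter), so the choice of group at this place clearly matters among these four compounds. Both of those sizes are only floors, and the true steps could be larger, as compound 2 and compound 3 are each reported as a limit rather than a number: the limit of > 100000 nM in this assay, at which 2 of the 4 values shown sit.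

Among the compounds shown here, the step between compound 2 and compound 3 cannot be read, and the single exchange from compound 1 to compound 4 removes the hydroxy and the fluorine while adding the nitro group, so it does not tell which of these changes accounts for the lower number. Also open, as far as these compounds go, is whether the nitro group must stay where it is in 3-nitrophenyl, and whether a phenyl ring carrying an amine or a carboxylic acid in its place would give a lower or a higher number.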